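The source may report more compounds than this note shows. Statements on the series, on what has been measured and on what is new or still open speak of the compounds shown alone.

Measured so far, in a physicochemical assay for acid dissociation: compound 1 `COc1cnc(C[S+]([O-])c2nc3cc(OC(F)F)ccc3[nH]2)cc1OC` gives 8.03; compound 2 `COc1cnc(C[S+]([O-])c2nc3cc(OC(F)F)ccc3[nH]2)c(C)c1OC` gives 8.35; compound 3 `COc1ccnc(C[S+]([O-])c2nc3cc(OC(F)(F)C(F)F)ccc3[nH]2)c1` gives 7.91.

Compound 1 and compound 2 differ in one place, (methyl in place of hydrogen on an aromatic carbon), and that change made a step of a number 0.32 log units higher from compound 1 to compound 2 (beyond the scatter). Compound 3 carries a different core; the difference between the two cores is not broken down here, and the values of compound 1 and compound 3 lie within the scatter of each other.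

Compound 4 `COc1cc(C[S+]([O-])c2nc3cc(OC(F)(F)C(F)F)ccc3[nH]2)ncc1C` is not yet measured. It stands to compound 3 as compound 2 stands to compound 1: methyl in place of hydrogen on an aromatic carbon. The surroundings are not identical: in compound 2 the methyl is ortho to a large group and meta to a methoxy group, whereas in compound 4 it is para to a large group. This is therefore the same kind of change, not the same change.

On that basis the step from compound 3 to compound 4 is expected to be about a number 0.32 log units higher from compound 3 to compound 4 (beyond the scatter), matching the step of a number 0.32 log units higher from compound 1 to compound 2 (beyond the scatter) seen for compound 1. For compound 4 a value of about 8.23 is estimated, likely between 8 and 8.5.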

Compound 4, acid dissociation constant: 8
Compound 4: middle estimate off by 0.23 log units, on the high side; low and high end bracket the measured number.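

In this assay, methyl in place of hydrogen on an aromatic carbon gave a number 0.32 log units higher from compound 1 to compound 2 (beyond the scatter) on the core of compound 1, but a number 0.09 log units higher from compound 3 to compound 4 (within the scatter) on the other core. For the compounds shown here, the single pair of steps thus shows that this kind of change did not carry over at a readable size, but it does not separate the effect of the core from that of position, as the methyl in compound 4 is ortho to a methoxy group and para to a large group and the methyl in compound 2 has different surroundings. Nothing shown here bears on why the two steps differ.

The compounds shown leave open how the two cores would compare with the methyl in matching surroundings. Also open, from the compounds shown here alone, is whether ethyl or an amine in place of that methyl would give a step beyond the scatter on either core.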